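Phenoxy for methyl in the working series

This account rests on a few compounds, and the source may have more. Where it says the series, first, only, none or still open, it means among the compounds named here.

Values in a functional assay on M21 cells (Homo sapiens) for antiproliferative activity, read by sulforhodamine B assay, with a stated time of 48 h; on this read-out higher numbers stand for weaker inhibition and lower numbers for stronger inhibition:
- compound 1 `Cc1cccc(NS(=O)(=O)c2ccc(N3CCNC3=O)cc2)c1`: 69 nM
- compound 2 `Cc1ccc(NS(=O)(=O)c2ccc(N3CCNC3=O)cc2)cc1C`: 94 nM
- compound 3 `O=C1NCCN1c1ccc(S(=O)(=O)Nc2cccc(Oc3ccccc3)c2)cc1`: not yet measured

Among the compounds with values here, compound 1 stands level with compound 2, the only other measured compound, as their values lie within the scatter of each other. Within the data shown here, the one measured step is a 1.4-fold higher number from compound 1 to compound 2 (0.13 log units; within the scatter), for methyl in place of hydrogen on an aromatic carbon.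

The next change is phenoxy in place of methyl on an aromatic carbon. In words, this is phenoxy in place of methyl on an aromatic carbon, meta to a large group. Among the measured compounds shown here, no measured compound carries phenoxy, so the methyl step offers only weak guidance for a group of this size. For the measured compounds named here, with a 1.4-fold higher number from compound 1 to compound 2 (0.13 log units; within the scatter) as the sole guide, a modest rise in the number is expected in this assay, though no shift beyond the scatter remains possible. The estimated step is a 2.0-fold higher number from compound 1 to compound 3 (0.31 log units; beyond the scatter). The estimate for compound 3 is 140 nM, with an expected range of 35 nM to 600 nM.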

Compound 3, half-maximal inhibitory concentration: 83 nM
Beside the measured number, compound 3's estimate is 1.7-fold (0.23 log units) above it, within the range that was stated.
By their numbers in this assay, from the lowest: compounds 1, 3 and 2 (each within the scatter of the next).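

In this assay, phenoxy in place of methyl gives a 1.2-fold higher number from compound 1 to compound 3 (0.08 log units; within the scatter) and so stays within the scatter, even though phenoxy brings 7 heavy atoms and one six-membered aromatic ring of carbon only where methyl has 1 heavy atom. Within the data shown here, this position on the aromatic ring therefore accepts a group much larger than methyl without a shift beyond the scatter, which the small methyl step between the earlier compounds could not show. No measured evidence bears on why the number holds across this change.

From the compounds shown here alone, it remains open whether the oxygen of phenoxy matters, which a directly attached phenyl or a benzyl group would test, and whether an amine or a carboxylic acid at this place would hold the number as well. Also open, going by these compounds, is whether a chlorine or a methoxy on the phenoxy ring would move the number beyond the scatter.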